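The source may report more compounds than this note shows. Statements on the series, on what has been measured and on what is new or still open speak of the compounds shown alone.

Compound 1 `COC(=O)C1=CO[C@@H](O[C@@H]2O[C@H](COC(c3ccccc3)(c3ccccc3)c3ccccc3)[C@@H](OC(=O)O)[C@H](OC(C)=O)[C@H]2OC(C)=O)[C@@H]2[C@@H](C)[C@@H](OC(C)=O)C[C@H]12`: 1.2 ug/mL
Compound 2 `CCCCCCCCCCCC(=O)OC[C@H]1O[C@@H](O[C@@H]2OC=C(C(=O)OC)[C@H]3C[C@H](OC(C)=O)[C@H](C)[C@@H]23)[C@H](OC(C)=O)[C@@H](OC(C)=O)[C@@H]1OC(C)=O`: 0.42 ug/mL

In a functional assay on PA-1 cells (Homo sapiens) for cytotoxicity, read by colony formation (on this read-out lower numbers stand for stronger inhibition and higher numbers for weaker inhibition), compound 2 gives the lower of the two numbers, 0.42 ug/mL, and the gap to compound 1 lies beyond the usual scatter. Compound 3 `COC(=O)C1=CO[C@@H](O[C@@H]2O[C@H](COC(=O)c3cccc([N+](=O)[O-])c3)[C@@H](OC(C)=O)[C@H](OC(C)=O)[C@H]2OC(C)=O)[C@@H]2[C@@H](C)[C@@H](OC(C)=O)C[C@H]12` differs from compound 2 by 3-nitrophenyl in place of undecyl on a carbonyl carbon, with 3-nitrophenyl in place of undecyl on a carbonyl carbon. Within the data shown here, no measured pair isolates this change, so the expectation is tentative. A modest move toward a higher number in this assay, meaning weaker inhibition, is expected, and the estimated size is a 1.9-fold higher number from compound 2 to compound 3 (0.28 log units; within the scatter). Compound 3 is expected at 0.8 ug/mL, within an estimated range of 0.3 ug/mL to 2.2 ug/mL.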

Compound 3, half-maximal inhibitory concentration: 2.65 ug/mL
The estimate for compound 3 lay 3.3-fold (0.52 log units) below the measured number; measured number above the stated range.
By their numbers in this assay, from the lowest: compound 2; then compound 1; then compound 3.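

At this position the group on the carbonyl carbon matters in this assay: putting 3-nitrophenyl in place of undecyl gives a 6.3-fold higher number from compound 2 to compound 3 (0.80 log units; beyond the scatter) and so weakens inhibition. This is the first pair shown that differs in one place, so the effect of this group alone could not be read from the earlier compounds. Nothing at hand explains the step. As far as these compounds go, it remains open whether a longer chain or a shorter chain would keep the number of compound 2, and whether plain phenyl would give that of compound 3. An amine in place of the nitro group on the ring is equally untested here.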